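A few compounds are considered here, and "the series" means these few. Any claim that something is new, unique, unknown or untested is made for them only; others in the source may bear on it.

In a functional assay on HL-60 cells (Homo sapiens) for antiproliferative activity, read by CCK-8 assay, with a stated time of 72 h (a higher number here means a weaker inhibitor, a lower number a stronger inhibitor), compound 1 `CC(=O)Oc1cc2c(CCC=C(C)C)c(C)ccc2cc1C(C)C` gives 20800 nM and compound 2 `CC(=O)Oc1cc2c(CC[C@@H]3OC(C)(C)OC3(C)C)c(C)ccc2cc1C(C)C` gives 16000 nM. Going by the values given here, these two numbers lie within the scatter of each other, so compound 2 stands level with the only other measured compound. Compound 3 `CC(=O)Oc1cc2c(CC[C@H]3OC(C)(C)OC3(C)C)c(C)ccc2cc1C(C)C` is the partner of compound 2 in configuration: the two compounds have the same atoms and bonds and differ only in configuration as drawn: 1 of 1 stereo elements differ; a stereocentre at a saturated ring carbon is drawn S in compound 2 and R in compound 3. Among the compounds with values here, no measured pair tests a change of configuration, so only one step bears on it, and only indirectly. That step, a 1.3-fold lower number from compound 1 to compound 2 (0.11 log units; within the scatter), exchanges 2-methylprop-1-en-1-yl for the whole 2,2,5,5-tetramethyl-1,3-dioxolan-4-yl group and stays within the scatter. With nothing larger measured, no change beyond the scatter is expected in this assay, and no direction is favoured. The expected step is a 1.1-fold higher number from compound 2 to compound 3 (0.03 log units; within the scatter). Compound 3 is estimated at 17000 nM, with an expected range of 9000 nM to 32000 nM.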

Compound 3, half-maximal inhibitory concentration: 17200 nM
Estimate against measurement, compound 3: 1.0-fold (0.01 log units) below; the measured number falls inside the stated range.
By their numbers in this assay, from the lowest: compounds 2, 3 and 1 (each within the scatter of the next).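

In this assay the change of configuration now has a direct reading (a 1.1-fold higher number from compound 2 to compound 3 (0.03 log units; within the scatter)), so drawing the stereocentre at the saturated ring carbon as S or as R does not separate the two compounds. The exchange of 2-methylprop-1-en-1-yl for 2,2,5,5-tetramethyl-1,3-dioxolan-4-yl also stays within the scatter with the R drawing (a 1.2-fold lower number from compound 1 to compound 3 (0.08 log units; within the scatter)), as it did with the S drawing. The configuration comparison is a clean one, with nothing else altered: the fact that compounds 2 and 3 differ only in the configuration as drawn.

Going by these compounds, whether an open-chain diol, a carboxylic acid, an amine or a longer chain in this place would move the number beyond the scatter stays open. Going by these compounds alone, also open is whether configuration would still make no difference in a compound carrying a hydroxyl in place of the acetate on the shared core.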